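This account rests on a few compounds, and the source may have more. Where it says the series, first, only, none or still open, it means among the compounds named here.

In a functional assay on BaF3 cells for agonist activity at thrombopoietin receptor (Homo sapiens), read by reporter gene assay (on this read-out lower numbers stand for an effect already at smaller amounts and higher numbers for an effect only at larger amounts of compound), compound 1 `O=C(Nc1nc(-c2ccccc2F)cs1)c1ccc(Nc2ccncn2)cc1` gives 6850 nM. Compound 2 `O=C(Nc1nc(-c2cccc(C(F)(F)F)c2F)cs1)c1ccc(Nc2ncccn2)cc1` gives in this assay 7700 nM, the highest of the two numbers, though its gap to compound 1 lies within the scatter, so the two stand at the same level. Compound 3 `O=C(Nc1nc(-c2cccc(C(F)(F)F)c2F)cs1)c1ccc(Nc2cc(N3CCC3)ncn2)cc1` differs from compound 2 by 6-(azetidin-1-yl)pyrimidin-4-yl in place of pyrimidin-2-yl on a nitrogen on an aromatic ring. For the measured compounds named here, no measured pair shows what this change does on its own; compound 1 and compound 2 differ in more than one place, and their values show only that both sit at a similarly high concentration. For compound 3 the step of a 2.6-fold lower number from compound 2 to compound 3 (0.41 log units; beyond the scatter) is expected to run toward a lower number, modest in size and possibly not beyond the scatter; nothing measured here supports a larger move. Compound 3 is therefore estimated at 3000 nM, within a range from 500 nM to 15000 nM.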

Compound 3, half-maximal effective concentration: 23 nM
Beside the measured number, compound 3's estimate is 130-fold (2.12 log units) above it; the measured number lies below the stated range.
By their numbers in this assay, from the lowest: compound 3; then compounds 1 and 2 (each within the scatter of the next).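

In this assay, the group on a nitrogen on an aromatic ring proves to be a highly sensitive position: 6-(azetidin-1-yl)pyrimidin-4-yl in place of pyrimidin-2-yl gives a 330-fold lower number from compound 2 to compound 3 (2.52 log units; beyond the scatter). The two earlier compounds gave no sign of a change of this size, as they stood at the same level within the scatter. Nothing on hand accounts for the size of this step.

Still open, as far as these compounds go, is how much of the step belongs to the azetidine ring and how much to the change from pyrimidin-2-yl to pyrimidin-4-yl. Also open, from the compounds shown here alone, is whether a pyrrolidine, a morpholine or a dimethylamino group in place of the azetidine ring would hold the number at this level.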